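The compounds below may be only part of what the source reports. "The series", "measured", "known", "first", "only" and "open" are said of these compounds alone.

Measured in a functional assay on L1210 cells (Mus musculus) for antiproliferative activity, with a stated time of 4 h; a higher number here means a weaker inhibitor, a lower number a stronger inhibitor:
- compound 1 `O=C1CCc2c1c1c(c3c2[nH]c2ccccc23)C(=O)NC1=O`: 58400 nM
- compound 2 `O=C1NC(=O)c2c1c1c(O)cccc1c1[nH]c3ccccc3c21`: 19200 nM
- compound 3 `Cc1ccc2[nH]c3c4c(=O)ccc(=O)c4c4c(=O)[nH]c(=O)c4c3c2c1`: 750 nM

Compound 2 holds the second highest of these three numbers in this assay, and its gaps to compound 1 and compound 3 both lie beyond the scatter. Compound 4 `O=C1NC(=O)c2c1c1c(O)ccc(O)c1c1[nH]c3ccccc3c21` differs from compound 2 by hydroxy in place of hydrogen on an aromatic carbon, para to a hydroxy group. Among the compounds with values here, no measured pair isolates this change. Within the data shown here, the only guide is compound 3 at 750 nM, whose oxygen pattern loosely resembles that of compound 4. A step to a lower number, beyond the scatter, is therefore expected, estimated as a 6.4-fold lower number from compound 2 to compound 4 (0.81 log units; beyond the scatter). The estimated value for compound 4 is 3000 nM, with an expected range of 600 nM to 15000 nM.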

Compound 4, half-maximal inhibitory concentration: 1100 nM
Estimate against measurement, compound 4: 2.7-fold (0.44 log units) above, within the range that was stated.
By their numbers in this assay, from the lowest: compounds 3 and 4 (each within the scatter of the next); then compound 2; then compound 1.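

In this assay, within the data shown here, the hydroxy in place of hydrogen, para to a hydroxy group, gives a 17-fold lower number from compound 2 to compound 4 (1.24 log units; beyond the scatter) and is the first change at a single place that can be read. It shows that this aromatic carbon of the shared core is a position where one added hydroxy moves the number by a large step, well beyond the scatter. No measurement given here explains the step.

On these data alone, whether an amine or a methoxy group at this position would give a similar step stays open, as does whether the step depends on the hydroxy group already present.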